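Swapping thiophenyl for ethynyl on a nucleoside core

A few compounds are considered here, and "the series" means these few. Any claim that something is new, unique, unknown or untested is made for them only; others in the source may bear on it.

In a functional assay on CEM-DNR-bulk cells (Homo sapiens), read by MTT assay, with a stated time of 72 h (a lower number here means a stronger inhibitor, a higher number a weaker inhibitor), compound 1 `C#Cc1cn([C@@H]2O[C@H](CO)[C@@H](O)[C@H]2O)c2ncnc(N(C)C)c12` gives 240 nM. Compound 2 `COc1ncnc2c1c(-c1cccs1)cn2[C@@H]1O[C@H](CO)[C@@H](O)[C@H]1O` gives 12100 nM in this assay, the highest of the two numbers shown, compound 1 being the only other numbered value. Compound 3 `CNc1ncnc2c1c(-c1cccs1)cn2[C@@H]1O[C@H](CO)[C@@H](O)[C@H]1O` reaches only a limit in this assay, > 20000 nM, which is the limit of > 20000 nM in this assay, at which 1 of the 3 values shown sits. Among the compounds with values here, the one measured step, an at least 1.6-fold higher number from compound 2 to compound 3 (0.21 log units; that floor lies within the scatter), alters a different position and does not bear directly on the present change. Compound 4 `C#Cc1cn([C@@H]2O[C@H](CO)[C@@H](O)[C@H]2O)c2ncnc(OC)c12` differs from compound 2 as follows: ethynyl in place of thiophen-2-yl on an aromatic carbon. Compound 1, which also carries ethynyl, gives the lower of the two numbers. The expected step is a 10-fold lower number from compound 2 to compound 4 (1.00 log units; beyond the scatter), toward a lower number. Compound 4 is therefore estimated at 1200 nM, with a range from 150 nM to 8000 nM.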

Compound 4, half-maximal inhibitory concentration: 3490 nM
For compound 4 the middle estimate is 2.9-fold (0.46 log units) below the measured one; measured number inside the range.
By their numbers in this assay, from the lowest: compound 1; then compound 4; then compound 2. At a limit, above all of these: compound 3.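

In this assay, ethynyl in place of thiophen-2-yl, two ring bonds from the ring nitrogen, gives a 3.5-fold lower number from compound 2 to compound 4 (0.54 log units; beyond the scatter), so this position responds to the change on a methoxy-bearing core. With ethynyl held constant, methoxy in place of dimethylamino gives a 15-fold higher number from compound 1 to compound 4 (1.16 log units; beyond the scatter), so the outcome also depends on the group at that second aromatic carbon. Nothing shown gives a cause for either step. On these data alone, whether thiophen-2-yl and ethynyl differ similarly alongside dimethylamino remains open. So does how a nitrile or a phenyl ring would fare at this position.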